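Series notes: three measured compounds and one pending analogue

The compounds below may be only part of what the source reports. "The series", "measured", "known", "first", "only" and "open" are said of these compounds alone.

Measured so far:
compound 1, `CC(O)(CSc1cc(C(F)(F)F)cc(C(F)(F)F)c1)C(=O)Nc1cccc(S(F)(F)(F)(F)F)c1`, 9400 nM
compound 2, `CC(O)(COc1cc(C(F)(F)F)cc(C(F)(F)F)c1)C(=O)Nc1cccc(S(F)(F)(F)(F)F)c1`, 9300 nM
compound 3, `CC(O)(COc1cc(C(F)(F)F)cc(C(F)(F)F)c1)C(=O)Nc1cccc(C(F)(F)C(F)(F)F)c1`, 9800 nM

The three measured compounds were run in a functional assay on DU-145 cells (Homo sapiens) for antiproliferative activity, read by propidium iodide staining, with a stated time of 96 h; a higher number here means a weaker inhibitor, a lower number a stronger inhibitor. Compound 1 gives 9400 nM, compound 2 gives 9300 nM and compound 3 gives 9800 nM; all three values sit within the scatter of one another, so no order among them can be read from these numbers.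

Compound 2 and compound 3 differ by one change, (a group of 7 heavy atoms (2 carbon, 5 fluorine; no ring) in place of a group of 6 heavy atoms (5 fluorine, 1 sulfur; no ring), on an aromatic carbon), and this change made a step of a 1.1-fold higher number from compound 2 to compound 3 (0.02 log units; within the scatter) in this assay. The two cores, that of compound 1 and that of compound 2, differ as well, but that difference is not broken down here; what the two values show is that they fall within the scatter of each other.

Compound 4, `CC(O)(CSc1cc(C(F)(F)F)cc(C(F)(F)F)c1)C(=O)Nc1cccc(C(F)(F)C(F)(F)F)c1`, has not yet been measured. It stands to compound 1 as compound 3 stands to compound 2: the change is a group of 7 heavy atoms (2 carbon, 5 fluorine; no ring) in place of a group of 6 heavy atoms (5 fluorine, 1 sulfur; no ring), on an aromatic carbon, and the place is the same word for word as in the step from compound 2 to compound 3, so it is the same change applied to the other core.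

Given that this change made a step of a 1.1-fold higher number from compound 2 to compound 3 (0.02 log units; within the scatter), the step from compound 1 to compound 4 in this assay is expected to be about a 1.0-fold higher number from compound 1 to compound 4 (0.02 log units; within the scatter), resting on that single measured step and on the value of compound 1, 9400 nM. Compound 4 is therefore estimated at 9800 nM, with a range from 5000 nM to 20000 nM.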

Compound 4, half-maximal inhibitory concentration: 8900 nM
Estimate against measurement, compound 4: 1.1-fold (0.04 log units) above; measured number inside the range.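

On the core of compound 1, putting 1,1,2,2,2-pentafluoroethyl in place of the group of five fluorine atoms and one sulfur atom, on an aromatic carbon, gives in this assay a step of a 1.1-fold lower number from compound 1 to compound 4 (0.02 log units; within the scatter). Set beside the same change on the other core, this step shows no difference between the cores that can be read: the same change on two cores in this assay, a 1.1-fold higher number (0.02 log units; within the scatter) from compound 2 to compound 3 and a 1.1-fold lower number (0.02 log units; within the scatter) from compound 1 to compound 4, 1.1-fold (0.05 log units) apart, within the scatter of two such steps. Among these compounds, this shows that the change left the number within the scatter on both cores, but since neither step is beyond the scatter, the printed directions carry no meaning, and the pair cannot show that a real effect of a given size passes from one core to the other; it also rests on only two cores and one assay.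

The compounds shown leave open whether a group of a different kind at this place, such as an amine, a carboxylic acid or a longer chain, would give a step beyond the scatter. They also leave open whether such a step would then carry from the core of compound 1 to the core of compound 2, a test that the four values here, all within a narrow band, cannot provide.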